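A larger group on the oxygen of compound 2

The source may hold more compounds than are shown below. What is called first, only, known or untested is meant among the compounds shown, and "the series" means these compounds.

Compound 1 (`Nc1ccc(-c2cc(=O)c3cc(O)ccc3o2)cc1`) and compound 2 (`COc1cc(-c2cc(=O)c3cc(O)ccc3o2)cc(OC)c1OC`) were both tested in a functional assay on Malme-3M cells (Homo sapiens) for cytotoxicity, read by MTT assay, with a stated time of 6 days; a lower number here means that less compound is needed, a higher number that more compound is needed for the effect. Compound 1 gives > 25 ug/mL, which is a limit. Compound 2 gives > 25 ug/mL, also a limit and not a number, so its standing rests on no exact value. The measured set therefore offers only (the limit of > 25 ug/mL in this assay, at which 2 of the 2 values shown sit). Compound 3 (`COc1cc(-c2cc(=O)c3cc(O)ccc3o2)cc(OC)c1O[Si](C)(C)C(C)(C)C`) differs from compound 2 by a group of 7 heavy atoms (6 carbon, 1 silicon; no ring) in place of one carbon atom, on an oxygen on an aromatic ring. Among the measured compounds shown here, with no measured step to draw on, no step beyond the scatter is expected in this assay, and the estimated change is a number no higher from compound 2 to compound 3 (the limit leaves the size open). Compound 3 is estimated at 25 ug/mL, with an expected range from 10 ug/mL to 50 ug/mL.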

Compound 3, concentration for half-maximal effect: 5.3 ug/mL
Estimate against measurement, compound 3: 4.7-fold (0.67 log units) above; measured number outside the range, below it.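

Putting the group of 7 heavy atoms (6 carbon, 1 silicon) in place of the methyl on this oxygen on an aromatic ring gives an at least 4.7-fold lower number from compound 2 to compound 3 (0.67 log units; beyond the scatter). Among the compounds shown here, the position therefore takes a much larger group, and the change brings the first exact number of the set in this assay.

The full size of the step stays open, because compound 2 carries only a limit: the limit of > 25 ug/mL in this assay, at which 2 of the 3 values shown sit. Whether the silicon matters also stays open, since a butyl or longer carbon chain on this oxygen, or a free hydroxyl there, is not among the compounds shown.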